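This account rests on a few compounds, and the source may have more. Where it says the series, first, only, none or still open, it means among the compounds named here.

Measured so far:
compound 1 `COc1ccc(S(=O)(=O)c2cnc3cc(F)ccc3c2-c2ccc(Cl)cc2)cc1` — 1.28 mL/min
compound 2 `COc1cccc(-c2c(S(=O)(=O)c3cc(F)cc(F)c3)cnc3cc(F)ccc23)c1` — 1.81 mL/min
compound 3 `O=S(=O)(c1cc(F)cc(F)c1)c1cnc2cc(F)ccc2c1-c1cccc(F)c1` — 0.06 mL/min

These three compounds share a core and were tested in an ADME assay on microsomes from liver (Homo sapiens) for metabolic stability, tested at 2.5 uM; a higher number here means faster removal of the compound, a lower number slower removal. Compound 3 stands lowest of the three; compound 1 is its nearest neighbour and compound 2 its furthest, both beyond the scatter.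

Compound 4 `COc1ccc(S(=O)(=O)c2cnc3cc(F)ccc3c2-c2cccc(F)c2)cc1` has not yet been measured. It differs from compound 3 in one place: 4-methoxyphenyl in place of 3,5-difluorophenyl on a sulfonyl sulfur.

Going by the values given here, only one measured step is available, and it does not involve the sulfonyl sulfur: the change a 30-fold lower number from compound 2 to compound 3 (1.48 log units; beyond the scatter) happened on an aromatic carbon. It does show that swapping a methoxy for a fluoro moved the number strongly downward, and the change to compound 4 runs the other way, bringing a methoxy in for fluorines. Compound 1, which also carries the 4-methoxyphenyl on its sulfonyl sulfur, sits far above compound 3.

For compound 4 a step of a 10-fold higher number from compound 3 to compound 4 (1.00 log units; beyond the scatter) is therefore expected, upward, and the estimated value is 0.6 mL/min, within 0.15 mL/min to 2 mL/min.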

Compound 4, intrinsic clearance in a liver preparation (reported as CLH), per the amount of preparation that the assay uses: 2.94 mL/min
The estimate for compound 4 lay 4.9-fold (0.69 log units) below the measured number, outside the stated range (above it).
By their numbers in this assay, from the lowest: compound 3; then compounds 1, 2 and 4 (each within the scatter of the next, the first and the last beyond it).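

The group on the sulfonyl sulfur proves to matter a great deal in this assay: 4-methoxyphenyl in place of 3,5-difluorophenyl gives a 49-fold higher number from compound 3 to compound 4 (1.69 log units; beyond the scatter), so this position can move the number as strongly as the aromatic carbon did. The other aromatic group has a smaller but real effect, with 3-fluorophenyl in place of 4-chlorophenyl giving a 2.3-fold higher number from compound 1 to compound 4 (0.36 log units; beyond the scatter), and compound 3, the lowest of the four, is the only one without a methoxy. Nothing shown explains why these numbers move as they do.

From the compounds shown here alone, it remains open whether the rise comes from gaining the methoxy or from losing the two fluorines, as a simple phenyl or a 4-fluorophenyl on the sulfonyl sulfur could separate the two. Going by these compounds, how this position would respond to a quite different group, such as an amine or a carboxylic acid, also remains unknown.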